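A few compounds are considered here, and "the series" means these few. Any claim that something is new, unique, unknown or untested is made for them only; others in the source may bear on it.

Working notes on the series. Three compounds have been run in an ADME assay on HEK293 cells (Homo sapiens) for cytotoxicity, read by CCK-8 assay and cell counting, with a stated time of 2 days; on this read-out higher numbers stand for weaker inhibition and lower numbers for stronger inhibition. Compound 1 `Oc1cccc(-c2cc(-c3ccc(Cl)cc3)nc(-c3ccccn3)c2)c1` gives 14000 nM in this assay. Compound 2 `Oc1cccc(-c2cc(-c3ccc(Cl)cc3)nc(-c3ccco3)c2)c1` gives 8190 nM in this assay; it differs from compound 1 by furan-2-yl in place of pyridin-2-yl on an aromatic carbon, and the step is a 1.7-fold lower number from compound 1 to compound 2 (0.23 log units; within the scatter). Compound 3 `Oc1ccc(-c2cc(-c3ccc(Cl)cc3)nc(-c3ccccn3)c2)cc1` gives 27200 nM in this assay; its core differs from the core of compound 1 by 4-hydroxyphenyl in place of 3-hydroxyphenyl on an aromatic carbon, and the step is a 1.9-fold higher number from compound 1 to compound 3 (0.29 log units; within the scatter). Compound 3 and compound 2 are not linked by a single change; their two values simply show compound 2 at the lower number and compound 3 at the higher, a gap that lies beyond the scatter.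

Compound 4 `Oc1ccc(-c2cc(-c3ccc(Cl)cc3)nc(-c3ccco3)c2)cc1` is not yet measured in this assay. It differs from compound 3 by furan-2-yl in place of pyridin-2-yl on an aromatic carbon. This is the same kind of change as that from compound 1 to compound 2, not the same change: in the earlier pair the place is meta to a 3-hydroxyphenyl group, here it is meta to a 4-hydroxyphenyl group. Within the data shown here, the only guide is the earlier step, a 1.7-fold lower number from compound 1 to compound 2 (0.23 log units; within the scatter), which is within the scatter. The step from compound 3 to compound 4 is expected to be a 1.7-fold lower number from compound 3 to compound 4 (0.23 log units; within the scatter), resting on the earlier pair having given a 1.7-fold lower number from compound 1 to compound 2 (0.23 log units; within the scatter). Compound 4 is therefore estimated at 16000 nM in this assay. For compound 4 the expected range runs from 8000 nM to 40000 nM.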

Compound 4, half-maximal inhibitory concentration: 5720 nM
Beside the measured number, compound 4's estimate is 2.8-fold (0.45 log units) above it, outside the stated range (below it).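

In this assay, furan-2-yl in place of pyridin-2-yl gives a 4.8-fold lower number from compound 3 to compound 4 (0.68 log units; beyond the scatter), and this step does not carry over at the same size from the core of compound 1: the same change on two cores in this assay, a 1.7-fold lower number (0.23 log units; within the scatter) from compound 1 to compound 2 and a 4.8-fold lower number (0.68 log units; beyond the scatter) from compound 3 to compound 4, 2.8-fold (0.44 log units) apart, beyond the scatter of two such steps The reverse view of the same four compounds gives a 1.4-fold lower number from compound 2 to compound 4 (0.16 log units; within the scatter) for 4-hydroxyphenyl in place of 3-hydroxyphenyl, and although each hydroxyphenyl step lies within the scatter on its own, the gap between them does not: the same change on two cores in this assay, a 1.9-fold higher number (0.29 log units; within the scatter) from compound 1 to compound 3 and a 1.4-fold lower number (0.16 log units; within the scatter) from compound 2 to compound 4, 2.8-fold (0.44 log units) apart, beyond the scatter of two such steps So in these four compounds the size of the furan-2-yl step depends on which hydroxyphenyl group the core carries, and a step read on one core is a poor guide to the other; this rests on a single set of four compounds, however, and shows neither a cause nor how the change would behave on any other core.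

Open, from the compounds shown here alone, is whether this dependence also appears with another ring in the same place, such as thiophen-2-yl or phenyl, or with an amine or a methoxy group in place of the hydroxy group. Also open, going by these compounds, is whether anything other than 4-chlorophenyl on the shared core, such as 4-fluorophenyl, leaves these steps as they stand.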